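Spirooxindole triazole series: halogenated phenyl swap on the aromatic nitrogen

A few compounds are considered here, and "the series" means these few. Any claim that something is new, unique, unknown or untested is made for them only; others in the source may bear on it.

Compound 1 `Cc1cccc(-n2nncc2CN2C(=O)C3(C(C#N)=C(N)Oc4c(N)cc5nc6ccccc6nc5c43)c3ccccc32)c1` carries a 3-methylphenyl on an aromatic nitrogen. In a functional assay on HCT-116 cells (Homo sapiens) for antiproliferative activity, read by MTT assay, with a stated time of 48 h (a lower number here means a stronger inhibitor, a higher number a weaker inhibitor), compound 1 gives only a limit, > 50000 nM. Compound 2 `N#CC1=C(N)Oc2c(N)cc3nc4ccccc4nc3c2C12C(=O)N(Cc1cnnn1-c1ccc(Cl)cc1)c1ccccc12` carries 4-chlorophenyl in place of 3-methylphenyl on that aromatic nitrogen. In this assay compound 2 likewise gives only a limit, > 50000 nM. The step that the two limits leave unreadable from compound 1 to compound 2 therefore cannot be sized. On the numbers shown, compound 2 stands at the limit, and both values shown sit there (the limit of > 50000 nM in this assay, at which 2 of the 2 values shown sit), so no compound in the series has yet returned a number.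

Compound 3 `N#CC1=C(N)Oc2c(N)cc3nc4ccccc4nc3c2C12C(=O)N(Cc1cnnn1-c1cccc(Br)c1)c1ccccc12` differs from compound 2 in one place: 3-bromophenyl in place of 4-chlorophenyl on an aromatic nitrogen. Among the compounds with values here, the only measured step that bears on this change, the swap from 3-methylphenyl to 4-chlorophenyl on the same aromatic nitrogen, is unreadable because both of its ends are limits (the limit of > 50000 nM in this assay, at which 2 of the 2 values shown sit). No readable step exists for any change at this position, so no direction beyond the scatter can be expected in this assay. Compound 3 is expected to stay at the limit, the expected step being a step that the limit leaves unreadable from compound 2 to compound 3. Compound 3 is estimated at 80000 nM, with a range from 30000 nM to 300000 nM.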

Compound 3, half-maximal inhibitory concentration: 26100 nM
For compound 3 the middle estimate is 3.1-fold (0.49 log units) above the measured one; the measured number lies below the stated range.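

In this assay, within the data shown here, compound 3 is the first to return a number rather than a limit, 26100 nM, so a change on this aromatic nitrogen can bring a value into the measurable range. Measured against the 4-chlorophenyl, 3-bromophenyl gives an at least 1.9-fold lower number from compound 2 to compound 3 (0.28 log units; that floor lies within the scatter), and measured against the 3-methylphenyl, with bromo in place of methyl, it gives an at least 1.9-fold lower number from compound 1 to compound 3 (0.28 log units; that floor lies within the scatter). Both figures are floors that lie within the scatter, so neither establishes a gain of any definite size, and the step with a limit at both ends cannot be read: the limit of > 50000 nM in this assay, at which 2 of the 3 values shown sit.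

Relative to the 4-chlorophenyl, 3-bromophenyl changes both the halogen and its place on the phenyl ring, so the compounds shown cannot separate the two changes; chloro in place of the bromo of 3-bromophenyl, or bromo in place of the chloro of 4-chlorophenyl, would do so. Also open, from the compounds shown here alone, is how far the value moves with a non-halogen group at the bromo's place, such as an amine or a carboxylic acid.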